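A few compounds are considered here, and "the series" means these few. Any claim that something is new, unique, unknown or untested is made for them only; others in the source may bear on it.

Compound 1, with the structure `CCCCOc1ccccc1C[C@H]1C(=O)OC[C@@H]1Cc1ccccc1`, was examined in a functional assay on HL-60 cells (Homo sapiens) for cytotoxicity, read by WST assay, with a stated time of 48 h (on this read-out higher numbers stand for an effect only at larger amounts of compound and lower numbers for an effect already at smaller amounts), where compound 1 gives 20000 nM. Compound 2, with the structure `Cc1ccccc1C[C@H]1C(=O)OC[C@@H]1Cc1ccccc1`, is related to compound 1 by a single change, (methyl in place of butoxy on an aromatic carbon), and in this assay compound 2 gives 57000 nM; this change produced a 2.9-fold higher number from compound 1 to compound 2 (0.45 log units; beyond the scatter). A third measured compound, compound 3, with the structure `CCCCOc1ccccc1C[C@H]1COC(=O)[C@@H]1Cc1ccc(Cl)c(Cl)c1`, gives 10000 nM in this assay. Compound 3 carries the same butoxy group as compound 1, but its core differs from that of compound 1, and the difference between the two cores is not broken down here; the two values show compound 3 and compound 1 lying within the usual scatter of each other, while the number for compound 2 stands well above both.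

Compound 4, with the structure `Cc1ccccc1C[C@H]1COC(=O)[C@@H]1Cc1ccc(Cl)c(Cl)c1`, has not yet been measured. It stands to compound 3 as compound 2 stands to compound 1, through (methyl in place of butoxy on an aromatic carbon), the same change at the same kind of place. Going by the values given here, for this assay the expectation rests on the one measured example of this change, which gave a 2.9-fold higher number from compound 1 to compound 2 (0.45 log units; beyond the scatter), so the step to compound 4 is expected to be of a similar size, a 2.9-fold higher number from compound 3 to compound 4 (0.46 log units; beyond the scatter). Starting from compound 3 and its value of 10000 nM, compound 4 is therefore estimated to give about 29000 nM in this assay, with the estimate expected to fall between 13000 nM and 65000 nM.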

Compound 4, half-maximal effective concentration: 22000 nM
Beside the measured number, compound 4's estimate is 1.3-fold (0.12 log units) above it, and the stated range covers the measured number.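

In this assay, methyl in place of butoxy on an aromatic carbon again raised the number, a step of a 2.2-fold higher number from compound 3 to compound 4 (0.34 log units; beyond the scatter). Set beside the earlier step, the change carried from the core of compound 1 to the core of compound 3 with no difference that can be told apart from the scatter: the same change on two cores in this assay, a 2.9-fold higher number (0.45 log units; beyond the scatter) from compound 1 to compound 2 and a 2.2-fold higher number (0.34 log units; beyond the scatter) from compound 3 to compound 4, 1.3-fold (0.11 log units) apart, within the scatter of two such steps. This shows that, for these two pairs and this one cytotoxicity read-out, the step kept its direction and a similar size, but it does not show that the step would hold on any further core, and two pairs give no reason for why the number moves.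

The compounds shown carry only butoxy or methyl at this place, so it stays open how a longer chain such as hexyloxy, a shorter one such as ethoxy, an amine or a carboxylic acid there would read in this assay. It also stays open what each of the differences between the two cores contributes on its own, including the two chlorine atoms of compound 3 and compound 4, since no pair shown changes any of them singly.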